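Trimethoxyphenyl pyrazole chalcones: swapping the ketone aryl

A few compounds are considered here, and "the series" means these few. Any claim that something is new, unique, unknown or untested is made for them only; others in the source may bear on it.

Measured compounds:
compound 1, `COc1cc(-c2cc(/C=C/C(=O)c3ccc(N)cc3)[nH]n2)cc(OC)c1OC`: 1650 nM
compound 2, `COc1ccc(-c2cc(/C=C/C(=O)c3ccc(OC)c(OC)c3)[nH]n2)cc1`: 1770 nM
compound 3, `COc1ccc(-c2cc(/C=C/C(=O)c3ccc(N)cc3)[nH]n2)cc1`: 2710 nM

Of the compounds shown here, three sharing a pyrazole-linked enone core have been tested in a functional assay on SK-MEL-5 cells (Homo sapiens) for inhibition, read by sulforhodamine B assay, with a stated time of 48 h; on this read-out lower numbers stand for stronger inhibition of growth and higher numbers for weaker inhibition of growth. Compound 1 gives 1650 nM, the lowest of the three numbers, but its distance to compound 2, which gives 1770 nM, and to compound 3, which gives 2710 nM, lies within the usual scatter of this read-out, so no order among the three can be claimed. Compound 2 and compound 3 carry the same aryl group on the shared core and differ only in the aryl group on the carbonyl; their two values sit close together.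

Compound 4, `COc1ccc(C(=O)/C=C/c2cc(-c3cc(OC)c(OC)c(OC)c3)n[nH]2)cc1OC`, has not yet been measured in this assay. It differs from compound 1 in one place: 3,4-dimethoxyphenyl in place of 4-aminophenyl on a carbonyl carbon. The same pairing of groups on the carbonyl, set against the same aryl on the core, appears in compound 2 versus compound 3, and there the values lie within the scatter. Going by the values given here, no step between measured compounds is available, so for this assay a change of no more than the scatter is expected, in either direction, with a slight lean toward a lower number given that compound 2 gives 1770 nM. The estimated step from compound 1 to compound 4 is a 1.2-fold lower number from compound 1 to compound 4 (0.07 log units; within the scatter). Compound 4 is accordingly expected to give about 1400 nM, within a range from 600 nM to 3500 nM.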

Compound 4, concentration for 50% growth inhibition: 1650 nM
Compound 4: the middle estimate sits 1.2-fold (0.07 log units) below what was measured; the range from low to high includes it.
By their numbers in this assay, from the lowest: compounds 1, 4, 2 and 3 (each within the scatter of the next).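

In this assay, going by these compounds alone, putting 3,4-dimethoxyphenyl in place of 4-aminophenyl on a carbonyl carbon gives no change at the digits printed from compound 1 to compound 4 (within the scatter), the first step that can be read directly from one single change. The same two groups also separate compound 3 at 2710 nM from compound 2 at 1770 nM, so two pairs with different aryl groups on the shared core now show no separation beyond the scatter, even though the group that enters has more heavy atoms and, unlike the group that leaves, no hydrogen-bond donor. No measurement shown here accounts for this result.

The compounds shown cover only these two aryl groups on the carbonyl carbon, so it remains open whether a carboxylic acid, a morpholine or a longer chain at that place would shift the number beyond the scatter. On these data alone, it also remains open whether any change at this place could reach a clearly lower number on this read-out, or whether a different aryl group on the core would alter the picture.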